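This account rests on a few compounds, and the source may have more. Where it says the series, first, only, none or still open, it means among the compounds named here.

Three compounds share a core in which an aromatic carbon, lying between two ring nitrogen atoms, carries a small amine group. Compound 1 `CCCNc1nc(NCc2ccc(C(=O)N3CCC(C(=O)NCc4ccc(F)cc4)CC3)cc2)c2ccccc2n1` gives 5700 nM in a functional assay on SW480 cells (Homo sapiens) for inhibition, read by luminescence and resazurin assay, with a stated time of 3 days; on this read-out lower numbers stand for stronger inhibition and higher numbers for weaker inhibition. Compound 2 `CNc1nc(NCc2ccc(C(=O)Nc3ccc(F)cc3)cc2)c2ccccc2n1` gives 4100 nM. Compound 3 `CC1CN(c2nc(NCc3ccc(C(=O)Nc4ccc(F)cc4)cc3)c3ccccc3n2)CCN1` gives 3200 nM, the lowest of the three numbers, though its gaps to compound 2 and to compound 1 both fall within the scatter, so no order can be read from them. Exchanging methylamino for 3-methylpiperazin-1-yl on that aromatic carbon produced a 1.3-fold lower number from compound 2 to compound 3 (0.11 log units; within the scatter).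

Compound 4 `O=C(Nc1ccc(F)cc1)c1ccc(CNc2nc(NC3CC3)nc3ccccc23)cc1` is the next step: cyclopropylamino in place of 3-methylpiperazin-1-yl on an aromatic carbon. Compound 1 also carries a small amine at this carbon, yet it differs from compound 3 elsewhere too, so only its value and that of compound 3 can be set side by side, and they lie within the scatter. Among the measured compounds shown here, the single direct comparison at this carbon, from compound 2 to compound 3, stayed within the scatter. The change to compound 4 is thus expected to be a 1.1-fold higher number from compound 3 to compound 4 (0.04 log units; within the scatter), within the scatter and with no firm direction. Compound 4 is therefore estimated at 3500 nM, with a range from 1500 nM to 8000 nM.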

Compound 4, half-maximal inhibitory concentration: 2600 nM
Compound 4: middle estimate off by 1.3-fold (0.13 log units), on the high side; measured number inside the range.
By their numbers in this assay, from the lowest: compounds 4, 3, 2 and 1 (each within the scatter of the next, the first and the last beyond it).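

Replacing 3-methylpiperazin-1-yl with cyclopropylamino on this aromatic carbon (a 1.2-fold lower number from compound 3 to compound 4 (0.09 log units; within the scatter)) exchanges a six-membered ring of 7 heavy atoms for a three-membered ring and its nitrogen, 4 heavy atoms in all. Cyclopropyl in place of methyl on the same nitrogen (a 1.6-fold lower number from compound 2 to compound 4 (0.20 log units; within the scatter)) adds a second exchange at this position, so in this assay compound 2, compound 3 and compound 4 now span three different groups there without any step leaving the scatter. Nothing measured on these compounds bears on this result.

The compounds shown leave open whether a plain amino group, a morpholin-4-yl ring or a carboxylic acid on this carbon would give a step beyond the scatter. They also leave open whether a longer chain on this nitrogen would do so.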